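A few compounds are considered here, and "the series" means these few. Any claim that something is new, unique, unknown or untested is made for them only; others in the source may bear on it.

In a functional assay on PC-3 cells (Homo sapiens) for inhibition, read by sulforhodamine B assay, with a stated time of 72 h (on this read-out lower numbers stand for stronger inhibition and higher numbers for weaker inhibition), compound 3 `Nc1sc(-c2ccc(Cl)cc2)c(-c2ccc(Cl)cc2)c1C(=O)NC1CCCC1` gives 21200 nM, the highest of the three numbers recorded. Compound 2 `Nc1sc(-c2ccc(Cl)cc2)c(-c2ccc(Cl)cc2)c1C(=O)NC1CCCCC1` gives 7300 nM and compound 1 `Nc1sc(-c2ccc(Cl)cc2)c(-c2ccc(Cl)cc2)c1C(=O)NC1CCC(O)CC1` gives 5670 nM; the steps were a 2.9-fold higher number from compound 2 to compound 3 (0.46 log units; beyond the scatter) and a 3.7-fold higher number from compound 1 to compound 3 (0.57 log units; beyond the scatter), while a 1.3-fold higher number from compound 1 to compound 2 (0.11 log units; within the scatter) lies within the scatter. Compound 4 `Nc1sc(-c2ccc(Cl)cc2)c(-c2ccc(Cl)cc2)c1C(=O)N1CCC(=O)CC1=O` differs from compound 3 by 2,4-dioxopiperidin-1-yl in place of cyclopentylamino on a carbonyl carbon. For the measured compounds named here, none of the measured steps bears directly on this change: they concern ring size on the amide-type nitrogen or a hydroxy group, not the loss of a hydrogen-bond donor and the gain of two acceptors on the carbonyl carbon. A step of a 1.2-fold higher number from compound 3 to compound 4 (0.07 log units; within the scatter) is therefore expected only loosely, in the direction of weaker inhibition. Compound 4 is estimated at 25000 nM, between 7000 nM and 90000 nM.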

Compound 4, half-maximal inhibitory concentration: 9230 nM
The estimate for compound 4 lay 2.7-fold (0.43 log units) above the measured number; the range from low to high includes it.
By their numbers in this assay, from the lowest: compounds 1, 2 and 4 (each within the scatter of the next); then compound 3.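

In this assay the step of a 2.3-fold lower number from compound 3 to compound 4 (0.36 log units; beyond the scatter) shows that 2,4-dioxopiperidin-1-yl on this carbonyl carbon, which removes the amide hydrogen, does not weaken inhibition relative to cyclopentylamino. The steps of a 1.3-fold higher number from compound 2 to compound 4 (0.10 log units; within the scatter) and a 1.6-fold higher number from compound 1 to compound 4 (0.21 log units; within the scatter) stay within the scatter, so among these compounds the amide hydrogen is not needed to match the cyclohexylamino and (4-hydroxycyclohexyl)amino amides. Nothing available explains this result. As far as these compounds go, it remains open whether either ring carbonyl matters, which plain piperidin-1-yl would test. Morpholin-4-yl or an open-chain diethylamino group on the same carbon also remains untested here.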